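Working notes: from compound 3 to compound 4

This account rests on a few compounds, and the source may have more. Where it says the series, first, only, none or still open, it means among the compounds named here.

compound 1 `CCCCCCCC[C@@]1(C)SC(O)=CC1=O`: 12.6 ug/mL
compound 2 `CCCCCCCC[C@@]1(C)SC(O)=C(C)C1=O`: 16.5 ug/mL
compound 3 `CCCCCCCC[C@@]1(C)SC(O)=C(C(C)=O)C1=O`: 12 ug/mL

In a functional assay on MCF7 cells (Homo sapiens) for inhibition (a higher number here means a weaker inhibitor, a lower number a stronger inhibitor), compound 3 gives 12 ug/mL, which stands within the scatter of both other compounds: a 1.1-fold lower number from compound 1 to compound 3 (0.02 log units; within the scatter) and a 1.4-fold lower number from compound 2 to compound 3 (0.14 log units; within the scatter). The remaining pair shows the same picture, with a 1.3-fold higher number from compound 1 to compound 2 (0.12 log units; within the scatter). Across these compounds, hydrogen, methyl and acetyl on the double-bonded ring carbon cannot be told apart on the numbers.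

The next compound, compound 4 `CCCCCCCC[C@@]1(C)SC(O)=C(C(=O)C(F)(F)F)C1=O`, carries a single change: trifluoromethyl in place of methyl on a carbonyl carbon. For the measured compounds named here, no measured step alters the group on that carbonyl carbon, so the evidence is only indirect. The closest guides are the two acetyl steps above, made on the double-bonded ring carbon, and neither leaves the scatter. Nothing in the data points to a direction. No shift beyond the scatter is therefore expected in this assay. The expected step is no change at the digits printed from compound 3 to compound 4 (within the scatter). For compound 4 the estimated value is 12 ug/mL, with an expected range of 6 ug/mL to 24 ug/mL.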

Compound 4, half-maximal inhibitory concentration: 14.7 ug/mL
For compound 4 the middle estimate is 1.2-fold (0.09 log units) below the measured one; the measured number falls inside the stated range.
By their numbers in this assay, from the lowest: compounds 3, 1, 4 and 2 (each within the scatter of the next).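

The group on the carbonyl carbon now has its first measured step. In this assay, trifluoromethyl in place of methyl on that carbon gives a 1.2-fold higher number from compound 3 to compound 4 (0.09 log units; within the scatter), so this change does not separate the two compounds on the numbers. The comparison also extends to the whole group on the double-bonded ring carbon: (trifluoromethyl)carbonyl in place of methyl gives a 1.1-fold lower number from compound 2 to compound 4 (0.05 log units; within the scatter), while (trifluoromethyl)carbonyl in place of hydrogen gives a 1.2-fold higher number from compound 1 to compound 4 (0.07 log units; within the scatter), which makes hydrogen, methyl, acetyl and (trifluoromethyl)carbonyl at this position indistinguishable in this read-out, and no evidence is available that bears on this flat result.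

The compounds shown do not settle whether any group on the double-bonded ring carbon can move the number beyond the scatter, since a carboxylic acid, an amine or a phenyl ring does not appear there, and a longer chain does not appear on the carbonyl carbon. They also leave open whether the same flat picture would hold on another cell line, or with changes made elsewhere on the shared core.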